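Swapping Fluoro for Bromo in Compound 2

The compounds below may be only part of what the source reports. "The series", "measured", "known", "first", "only" and "open" are said of these compounds alone.

Of the compounds shown here, two have so far been measured in an in vivo ADME assay on the whole organism (plasma) for pharmacokinetics, with Rattus norvegicus as the target; on this read-out higher numbers stand for fast clearance and lower numbers for slow clearance. Compound 1 `CN(C)c1nccc2ccc(/C=C\C(=O)Nc3ccc(-c4ccccc4S(N)(=O)=O)cc3)cc12` gives 56.4 mL/min/kg in this assay, while compound 2 `C/C(=C(\F)C(=O)Nc1ccc(-c2ccccc2S(N)(=O)=O)cc1F)c1ccc2ccnc(N)c2c1` gives 25.3 mL/min/kg, the lower of the two numbers, with the gap to compound 1 lying beyond the usual scatter. Compound 3 `C/C(=C(\F)C(=O)Nc1ccc(-c2ccccc2S(N)(=O)=O)cc1Br)c1ccc2ccnc(N)c2c1` differs from compound 2 only by bromo in place of fluoro on an aromatic carbon. Going by the values given here, no measured pair shows this change, so the expected step from compound 2 to compound 3 is a 1.1-fold higher number from compound 2 to compound 3 (0.04 log units; within the scatter), small and within the scatter in either direction. Compound 3 is therefore estimated at 28 mL/min/kg, with a range from 14 mL/min/kg to 56 mL/min/kg.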

Compound 3, clearance: 4.4 mL/min/kg
The estimate for compound 3 lay 6.4-fold (0.80 log units) above the measured number; the measured number lies below the stated range.
By their numbers in this assay, from the lowest: compound 3; then compound 2; then compound 1.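

Bromo in place of fluoro at this place, ortho to a large group and meta to a 2-sulfamoylphenyl group, is far from a neutral swap: in this assay the change gives a 5.8-fold lower number from compound 2 to compound 3 (0.76 log units; beyond the scatter) and lies beyond the scatter. This one halogen on the aromatic ring therefore has a clear bearing on clearance in the rat. Nothing measured here gives a reason for this step.

On these data alone, whether chloro, iodo or a methoxy group at this place would shift the number in the same way remains open. So does whether the same swap would act alike on the core of compound 1.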